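Lengthening the amine side chain on a shared core

The source may report more compounds than this note shows. Statements on the series, on what has been measured and on what is new or still open speak of the compounds shown alone.

Compound 1 `CC(C)NC1=NS(=O)(=O)c2cc(Cl)ccc2N1` gives 36300 nM in a functional assay (aorta) with Rattus norvegicus as the target, with a stated time of 90 min, at 37 degrees C; a higher number here means that more compound is needed for the effect, a lower number that less compound is needed.
Compound 2 `CCCNC1=NS(=O)(=O)c2cc(Cl)c(Cl)cc2N1` gives 4700 nM in this assay.
Compound 3 `O=S1(=O)NC(NC2CC2)=Nc2cc(Cl)c(Cl)cc21` gives only a limit of the assay, > 30000 nM, in this assay.

Among the two numbers that are numbers, compound 2 stands lowest, and compound 1 sits higher by a gap that lies beyond the usual scatter. Compound 3 returns no number at all but a limit, (the limit of > 30000 nM in this assay, at which 1 of the 3 values shown sits), so it cannot be placed against the other two beyond saying that its result is a limit.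

Compound 4 `CCCCCCNC1=NS(=O)(=O)c2cc(Cl)c(Cl)cc2N1` is built from compound 2 by one change: propyl in place of hydrogen on a saturated chain carbon, three bonds along the chain from an amine nitrogen. Among the compounds with values here, none of the measured compounds differ from one another in a single place, so no measured step tells how this kind of lengthening of the chain behaves in this assay. What can be said rests only on compound 2 and its value 4700 nM, taken as the starting point. The step from compound 2 to compound 4 is expected to be a 1.3-fold lower number from compound 2 to compound 4 (0.13 log units; within the scatter), that is, a change not clearly beyond the scatter of the assay, with no firm direction. On that basis compound 4 is estimated at 3500 nM in this assay, with a range from 900 nM to 14000 nM.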

Compound 4, half-maximal effective concentration: > 300000 nM
Compound 4: a limit, no number (the forecaster's own chance of this, stated with the estimate: 10%); at least 85-fold (1.93 log units) between middle value and limit.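

Within the data shown here, the pair of compound 2 and compound 4 gives the first step here between compounds that differ in one place, and it shows that the amine side chain is not a free position for lengthening. In this assay, propyl in place of hydrogen on a saturated chain carbon, three bonds along the chain from an amine nitrogen, gives an at least 63-fold higher number from compound 2 to compound 4 (1.80 log units; beyond the scatter), so the change from a propyl to a hexyl side chain is a large one in the direction of needing more compound. Compound 4 gives a limit of the assay rather than a number, so this step has a lower bound but no exact size: the limit of > 300000 nM in this assay, at which 1 of the 4 values shown sits.

The data show neither why the hexyl chain has this effect nor where between propyl and hexyl the change sets in, which a butyl or a pentyl chain on the same core could help to locate. A hydroxyl group at the end of the hexyl chain could likewise help to show whether chain length alone governs the result.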